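Series notes: from compound 2 to compound 4

This account rests on a few compounds, and the source may have more. Where it says the series, first, only, none or still open, it means among the compounds named here.

Compound 2 `CC(=O)C(=O)NCCCCCC(=O)Nc1ccccc1` is one of three measured members, alongside compound 1 `C/C(=N\O)C(=O)NCCCCCC(=O)Nc1ccccc1` and compound 3 `CC(=O)C(=O)NCCCCCCC(=O)Nc1ccccc1`. In a functional assay on HCT-116 cells (Homo sapiens) for inhibition, read by colorimetric assay, with a stated time of 3 days (on this read-out higher numbers stand for weaker inhibition and lower numbers for stronger inhibition), compound 2 gives only a limit, > 100000 nM. Compound 1 likewise gives only a limit, > 100000 nM. Compound 3 also gives only a limit, > 100000 nM. The three steps among them, a step that the two limits leave unreadable from compound 1 to compound 2, a step that the two limits leave unreadable from compound 1 to compound 3 and a step that the two limits leave unreadable from compound 2 to compound 3, are accordingly unreadable, as the limit of > 100000 nM in this assay, at which 3 of the 3 values shown sit, records. Compound 4 `CC(C)(C)C(O)(O)C(=O)NCCCCCC(=O)Nc1ccccc1` differs from compound 2 by 1,1-dihydroxy-2,2-dimethylpropyl in place of acetyl on a carbonyl carbon. Going by the values given here, no measured step touches this change, so nothing indicates a direction in this assay. With every value at the limit, compound 4 is expected to remain there, with 100000 nM spanning 50000 nM to 300000 nM. The expected step of a number no higher from compound 2 to compound 4 (the limit leaves the size open) is taken as none beyond the scatter.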

Compound 4, half-maximal inhibitory concentration: 54400 nM
Compound 4: the middle estimate sits 1.8-fold (0.26 log units) above what was measured; low and high end bracket the measured number.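

In this assay, going by these compounds alone, compound 4 is the only one of the four compounds to give a number rather than a limit, so a change on this carbonyl carbon can now be read at least as a floor. 1,1-Dihydroxy-2,2-dimethylpropyl in place of acetyl gives an at least 1.8-fold lower number from compound 2 to compound 4 (0.26 log units; that floor lies within the scatter), and the comparison with the oxime-bearing member gives an at least 1.8-fold lower number from compound 1 to compound 4 (0.26 log units; that floor lies within the scatter). The full size of both steps stays open, and the steps among compound 1, compound 2 and compound 3 cannot be read, because of the limit: the limit of > 100000 nM in this assay, at which 3 of the 4 values shown sit.

Still open is which part of the entering group carries the step, since a plain tert-butyl group or a carboxylic acid on this carbonyl carbon is not among the compounds shown. Also open, as far as these compounds go, is whether a longer chain would hold the number with 1,1-dihydroxy-2,2-dimethylpropyl in place.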